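Swapping One Aromatic Ring Group on Compound 3

The source may report more compounds than this note shows. Statements on the series, on what has been measured and on what is new or still open speak of the compounds shown alone.

Among the measured compounds shown here, in a physicochemical assay for solubility, measured as kinetic solubility, at pH 6.5 (a lower number here means a less soluble compound, a higher number a more soluble compound), three related compounds have numbers so far. Compound 1 `Fc1ccc(-c2ccc3nnc(Cc4ccc5ncccc5c4)n3n2)cc1F` stands at 11500 nM and compound 2 `Nc1ccc2nnc(Cc3ccc4ncccc4c3)n2n1` at 453000 nM while compound 3 `COc1ccc(-c2ccc3nnc([C@@H](C)c4ccc5ncccc5c4)n3n2)cc1C` has 1770 nM as the lowest of the three.

The next compound is compound 4 `C[C@@H](c1ccc2ncccc2c1)c1nnc2ccc(-c3ccc(N(C)C)nc3)nn12` which keeps the core of compound 3 and carries 6-(dimethylamino)pyridin-3-yl in place of 4-methoxy-3-methylphenyl on an aromatic carbon. The difference is 6-(dimethylamino)pyridin-3-yl in place of 4-methoxy-3-methylphenyl on an aromatic carbon and nothing else in the molecule changes. A six-membered aromatic ring of carbon only gives way to a six-membered aromatic ring with 1 hetero atom.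

For the measured compounds named here, only one measured step bears on this swap. It is a 39-fold higher number from compound 1 to compound 2 (1.60 log units; beyond the scatter) and it is large, with amino in place of 3,4-difluorophenyl on an aromatic carbon. That step removes the aromatic ring altogether, whereas compound 4 still has one, and compound 1 also differs from compound 3 elsewhere, so the guide is a loose one. Going by the values given here, with a 39-fold higher number from compound 1 to compound 2 (1.60 log units; beyond the scatter) as the only precedent, a rise is expected here too, though a much smaller one. The expected step is a 3.4-fold higher number from compound 3 to compound 4 (0.53 log units; beyond the scatter) in this assay and this estimate carries wide margins. For compound 4 the estimated value is 6000 nM with an expected range from 1500 nM to 25000 nM as its upper end.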

Compound 4, solubility: 16200 nM
Compound 4: middle estimate off by 2.7-fold (0.43 log units), on the low side; the measured number falls inside the stated range.
By their numbers in this assay, from the lowest: compound 3; then compounds 1 and 4 (each within the scatter of the next); then compound 2.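

In this assay, the swap at this position gives a 9.2-fold higher number from compound 3 to compound 4 (0.96 log units; beyond the scatter), which shows that the number can move beyond the scatter while an aromatic ring stays in place. Among the compounds shown here, the only earlier step, a 39-fold higher number from compound 1 to compound 2 (1.60 log units; beyond the scatter), removed the aromatic ring altogether, and it could not show this. The leaving and entering groups also match in several counts, with 9 heavy atoms, one six-membered aromatic ring and no net charge each, so a clear step here needs no change in any of those counts, and nothing measured here gives a reason for the rise.

The swap changes two things at once, a ring nitrogen in place of a ring carbon and dimethylamino in place of the methoxy and methyl groups, and the compounds shown cannot say how much of the step belongs to each. From the compounds shown here alone, a plain pyridin-3-yl at this position would help to separate the two, and how a morpholine in place of the dimethylamino group would read in this assay remains open as well.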